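This account rests on a few compounds, and the source may have more. Where it says the series, first, only, none or still open, it means among the compounds named here.

Measured compounds:
Compound 1 `CCS(=O)(=O)N1CCC2(CC1)OOC1(CCCCC1)OO2`: > 100 ug/mL (a limit)
Compound 2 `CCCS(=O)(=O)N1CCC2(CC1)OOC1(CCCCC1)OO2`: > 100 ug/mL (a limit)
Compound 3 `O=S(=O)(CCCCl)N1CCC2(CC1)OOC1(CCCCC1)OO2`: > 100 ug/mL (a limit)

All three were tested in a functional assay on Huh-7 cells (Homo sapiens) for cytotoxicity, read by MTT assay, with a stated time of 72 h; on this read-out lower numbers stand for higher toxicity in this test and higher numbers for lower toxicity in this test. Compound 3 gives no number there, only the limit > 100 ug/mL. It shares this position with the other two compounds, as the limit of > 100 ug/mL in this assay, at which 3 of the 3 values shown sit, records.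

Compound 4 `O=S(=O)(Cc1ccccc1)N1CCC2(CC1)OOC1(CCCCC1)OO2` is the next to be considered. The change is phenyl in place of 2-chloroethyl on a saturated chain carbon bound to a sulfonyl sulfur. Put another way, it is 3-chloropropyl to benzyl.

The steps bearing on this change concern the same chain: a step that the two limits leave unreadable from compound 1 to compound 2, a step that the two limits leave unreadable from compound 1 to compound 3 and a step that the two limits leave unreadable from compound 2 to compound 3. Among the compounds with values here, none has a readable size, and none of the measured compounds carries an aromatic ring. The data therefore give no direction for this assay, and no change beyond the scatter is expected. The expected step is a number no higher from compound 3 to compound 4 (the limit leaves the size open). For compound 4 the estimated value is 100 ug/mL, with an expected range from 40 ug/mL to 200 ug/mL.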

Compound 4, half-maximal cytotoxic concentration: > 100 ug/mL
Compound 4 ended at the assay's limit; the forecaster's own chance of this, stated with the estimate: 70%; the middle value lies on the limit itself.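

In this assay compound 4 gives > 100 ug/mL, a limit, and its steps from compound 1, compound 2 and compound 3 cannot be read: the limit of > 100 ug/mL in this assay, at which 4 of the 4 values shown sit. The compounds shown leave open whether any change on the chain bound to the sulfonyl sulfur alters the read-out in this assay at all.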